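The source may hold more compounds than are shown below. What is called first, only, known or untested is meant among the compounds shown, and "the series" means these compounds.

In an assay on brain for displacement of a labelled ligand from Neuronal acetylcholine receptor; alpha4/beta2 (Rattus norvegicus) (on this read-out higher numbers stand for weaker inhibition and lower numbers for stronger inhibition), compound 1, `CNC1(COc2cccnc2)CC1`, gives 3 nM. Compound 2, `CN(C)C1(COc2cccnc2)CC1`, differs from compound 1 by methyl in place of hydrogen on an amine nitrogen, and in this assay compound 2 gives 95 nM, so that the step is a 32-fold higher number from compound 1 to compound 2 (1.50 log units; beyond the scatter). Compound 3, `CNC1(COc2cnc(Cl)c(Br)c2)CC1`, has a different core from compound 1; the difference between the two cores is not broken down here. In this assay compound 3 gives 5.37 nM, a number that lies within the scatter of the value for compound 1 and well below the value for compound 2.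

Compound 4, `CN(C)C1(COc2cnc(Cl)c(Br)c2)CC1`, has not yet been measured in this assay. It differs from compound 3 by methyl in place of hydrogen on an amine nitrogen, the same change that separates compound 1 from compound 2, at a place described in the same words. Because a 32-fold higher number from compound 1 to compound 2 (1.50 log units; beyond the scatter) is large and lies far beyond the scatter, the step from compound 3 to compound 4 is expected to be of similar size, a 32-fold higher number from compound 3 to compound 4 (1.50 log units; beyond the scatter). Compound 4 is therefore estimated at 170 nM, with a likely range from 60 nM to 500 nM.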

Compound 4, inhibition constant: 110 nM
Estimate against measurement, compound 4: 1.5-fold (0.19 log units) above, and the stated range covers the measured number.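

In this assay, methyl in place of hydrogen on an amine nitrogen again brings a large loss of binding on the second core, with a 20-fold higher number from compound 3 to compound 4 (1.31 log units; beyond the scatter). Set beside the earlier step, the change carries over from one core to the other with its size intact within the scatter: the same change on two cores in this assay, a 32-fold higher number (1.50 log units; beyond the scatter) from compound 1 to compound 2 and a 20-fold higher number (1.31 log units; beyond the scatter) from compound 3 to compound 4, 1.5-fold (0.19 log units) apart, within the scatter of two such steps This agreement rests on only two matched pairs, one change and one assay, so it shows neither that the step would keep its size on any further core nor why the added methyl has this effect.

The compounds shown carry only hydrogen or methyl as the variable group on that nitrogen, which leaves open whether ethyl or a longer chain there would bring a step of like size or a larger one. They also leave open whether the same step would appear on a core bearing fluorine or a methoxy group in place of the chlorine and bromine of compound 3.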